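A few compounds are considered here, and "the series" means these few. Any claim that something is new, unique, unknown or untested is made for them only; others in the source may bear on it.

Measured so far in an assay for inhibition of solute carrier family 22 member 12 (Homo sapiens), read by scintillation counting, with a stated time of 60 min, tested at 50 uM; on this read-out higher numbers stand for more inhibition at the one concentration tested (going by the name of the read-out) and lower numbers for less inhibition:

- compound 1, `CCc1oc2c(OC)cccc2c1C(=O)c1ccc(OC)cc1`, gives 17.2%
- compound 2, `CCc1cc2cc(O)cc(C(=O)c3ccc(OC)cc3)c2o1`, gives 9.3%
- compound 3, `CCc1cc2cc(O)cc(C(=O)c3ccc(O)cc3)c2o1`, gives 41%

Compound 1 and compound 2 carry different cores; the difference between the two cores is not broken down here. Their values in this assay lie within the scatter of each other, so nothing is read from that pair. Compound 3 differs from compound 2 in one place only, (hydrogen in place of methyl on an oxygen on an aromatic ring), and this change gives a number 31.7 percentage points higher from compound 2 to compound 3 (beyond the scatter). Going by the values given here, it is the one step in the set that lies beyond the scatter, and it is the only time this change has been measured.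

Compound 4, `CCc1oc2c(O)cccc2c1C(=O)c1ccc(OC)cc1`, is not yet measured. It differs from compound 1 by hydrogen in place of methyl on an oxygen on an aromatic ring. The place lines of the two changes read alike, so the change from compound 1 to compound 4 is the same change as that from compound 2 to compound 3, made on the other core. Going by these compounds, for compound 4 the expected step is a number 18.8 percentage points higher from compound 1 to compound 4 (beyond the scatter), which is set somewhat smaller than the measured step because a number 31.7 percentage points higher from compound 2 to compound 3 (beyond the scatter) rests on a single pair and is carried over to a core whose own response to this change is unknown. With that step compound 4 is estimated at 36%, between 15% and 57%.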

Compound 4, a percentage reported as inhibition, at one concentration (the size of the read-out at that concentration, not a potency): 18.2%
Compound 4: the middle estimate sits 17.8 percentage points above what was measured; low and high end bracket the measured number.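

In this assay, methoxy to hydroxy on the core of compound 1 gives a number 1 percentage points higher from compound 1 to compound 4 (within the scatter), so the rise seen on the other core does not reappear here. The change therefore cannot be carried from one core to the other in this series as a fixed increment, and the two measured instances disagree: the same change on two cores in this assay, a number 31.7 percentage points higher (beyond the scatter) from compound 2 to compound 3 and a number 1 percentage points higher (within the scatter) from compound 1 to compound 4, 30.7 percentage points apart, beyond the scatter of two such steps. This does not show what sets the gap: with a single pair on each core, the data cannot separate the influence of the core from that of the surroundings of the oxygen that changes, and they cannot show whether either step is typical of its core.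

The compounds shown leave open how the core of compound 1 responds when the methoxy on its other ring is changed to hydroxy, and whether a compound with hydroxy in both places would follow compound 3 or compound 4. They also leave open whether a carboxylic acid or an amine in place of the hydroxy, or a longer chain in place of the ethyl, would move the inhibition on either core.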